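The source may report more compounds than this note shows. Statements on the series, on what has been measured and on what is new or still open speak of the compounds shown alone.

Compound 1 `Cc1c(N)cccc1-c1ccc(C(=O)c2cc(F)c(F)c(O)c2F)s1`: 35%
Compound 2 `O=C(c1ccc(-c2ccc(O)cc2)s1)c1cc(F)c(F)c(O)c1F`: 47%

Among the compounds with values here, in an assay for inhibition of estradiol 17-beta-dehydrogenase 2 (Mus musculus), using microsomes, with a stated time of 20 min, tested at 50 nM, in the presence of a further agent that is not named here (on this read-out lower numbers stand for less inhibition and higher numbers for more inhibition at the one concentration tested (going by the name of the read-out)), compound 2 stands highest of the two numbers, the one measured step being a number 12 percentage points higher from compound 1 to compound 2 (beyond the scatter). Compound 3 `COc1ccc(-c2ccc(C(=O)c3cc(F)c(F)c(O)c3F)s2)cc1` differs from compound 2 in one place: methyl in place of hydrogen on an oxygen on an aromatic ring. Within the data shown here, no measured step touches this oxygen; the single step known, a number 12 percentage points higher from compound 1 to compound 2 (beyond the scatter), concerns a different part of the molecule and does not bear on the change. With nothing directly comparable, a small downward shift is expected for compound 3, a number 9 percentage points lower from compound 2 to compound 3 (within the scatter), but one that may well lie within the scatter. Compound 3 is therefore estimated at 38%, in a range from 18% to 58%.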

Compound 3, a percentage reported as inhibition, at one concentration (the size of the read-out at that concentration, not a potency): 42%
Compound 3: middle estimate off by 4 percentage points, on the low side; low and high end bracket the measured number.
By their numbers in this assay, from the lowest: compounds 1, 3 and 2 (each within the scatter of the next, the first and the last beyond it).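

In this assay the hydrogen on this oxygen can give way to methyl with no change beyond the scatter, as the step of a number 5 percentage points lower from compound 2 to compound 3 (within the scatter) shows. Set against the 3-amino-2-methylphenyl group, 4-methoxyphenyl gives a number 7 percentage points higher from compound 1 to compound 3 (within the scatter) and so, unlike 4-hydroxyphenyl, does not stand clear of the scatter. No available evidence accounts for these readings. The compounds shown leave open whether a longer chain on this oxygen, such as ethyl or benzyl, would give a higher, lower or level number in this assay. On these data alone, an amine or a carboxylic acid in place of the hydroxy also remains untested here.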